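Replacing the phenylethynyl arm of compound 3 with a dichlorophenyl ring

The compounds below may be only part of what the source reports. "The series", "measured", "known", "first", "only" and "open" are said of these compounds alone.

Compound 3 `O=C(NO)[C@H]1CCCC1S(=O)(=O)c1ccc(C#Cc2ccccc2)cc1` holds the lowest of the three numbers shown. In an assay on isolated protein for inhibition of matrix metalloproteinase-9 (Homo sapiens), read by fluorescence, with stated times of 5 min and 30 min (on this read-out higher numbers stand for weaker inhibition and lower numbers for stronger inhibition), compound 3 gives 0.91 nM. Its nearest neighbour is compound 2 `COc1ccc(S(=O)(=O)C2CCC[C@@H]2C(=O)NO)cc1`, which in this assay gives 22 nM; the furthest is compound 1 `O=C(NO)[C@H]1CCCC1S(=O)(=O)c1ccc(Cl)c(Cl)c1`, which in this assay gives 4370 nM. For the measured compounds named here, the one step between measured compounds that differ in a single place is a 24-fold lower number from compound 2 to compound 3 (1.38 log units; beyond the scatter).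

Compound 4 `O=C(NO)[C@H]1CCCC1S(=O)(=O)c1ccc(-c2ccc(Cl)c(Cl)c2)cc1` differs from compound 3 as follows: 3,4-dichlorophenyl in place of 2-phenylethynyl on an aromatic carbon. Going by the values given here, no measured step exchanges one large group for another on that aromatic carbon, so the step from compound 2 to compound 3 bears on it only by showing how strongly that position responds. Compound 1 carries the same 3,4-dichlorophenyl ring, but attached directly to the sulfonyl, and its value stands far above that of compound 3. On this basis compound 4 is expected to stay close to compound 3, with a 2.2-fold higher number from compound 3 to compound 4 (0.34 log units; beyond the scatter) as the estimated step. Compound 4 is therefore estimated at 2 nM, in a range from 0.4 nM to 10 nM.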

Compound 4, half-maximal inhibitory concentration: 0.76 nM
Estimate against measurement, compound 4: 2.6-fold (0.42 log units) above, within the range that was stated.
By their numbers in this assay, from the lowest: compounds 4 and 3 (each within the scatter of the next); then compound 2; then compound 1.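

In this assay the exchange of 2-phenylethynyl for 3,4-dichlorophenyl on this aromatic carbon gives a 1.2-fold lower number from compound 3 to compound 4 (0.08 log units; within the scatter) so this position does not separate these two large groups, although only one of them holds a triple bond. The triple bond is therefore not needed for a low number here: a 29-fold lower number from compound 2 to compound 4 (1.46 log units; beyond the scatter) stands alongside a 24-fold lower number from compound 2 to compound 3 (1.38 log units; beyond the scatter) as a large step away from methoxy, and both lie beyond the scatter. No measurement offered here explains why the two groups give such similar numbers.

The compounds shown leave open whether the two chlorines contribute anything, which a plain phenyl ring at this position would test. They also leave open whether a longer alkyl chain, or an aryl group carrying an amine or a carboxylic acid, would keep the number as low as in compound 3 and compound 4.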